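A few compounds are considered here, and "the series" means these few. Any claim that something is new, unique, unknown or untested is made for them only; others in the source may bear on it.

Measured so far in a functional assay on HCT-116 cells (Homo sapiens) for inhibition, read by MTT assay, with a stated time of 72 h; a lower number here means a stronger inhibitor, a higher number a weaker inhibitor:
- compound 1 `COc1cc2c(Oc3ccc(NC(=O)c4nn(-c5ccccc5C)cc(C)c4=O)cc3)ccnc2cc1OCCCC(=O)NO`: 640 nM
- compound 2 `COc1cc2c(Oc3ccc(NC(=O)c4nn(-c5ccc(C)cc5C)cc(C)c4=O)cc3)ccnc2cc1OCCCCCCC(=O)NO`: 440 nM
- compound 3 `COc1cc2c(Oc3ccc(NC(=O)c4nn(-c5ccccc5C)cc(C)c4=O)cc3)ccnc2cc1OCCCCCC(=O)NO`: 290 nM

Compound 3 lies beyond the scatter from compound 1 on the lower side and within the scatter of compound 2. The next change leads to compound 4 `COc1cc2c(Oc3ccc(NC(=O)c4nn(-c5ccccc5C)cc(C)c4=O)cc3)ccnc2cc1OCCCCCCC(=O)NO`: (hydroxycarbamoyl)methyl in place of hydroxycarbamoyl on a saturated chain carbon, five bonds along the chain from an oxygen on an aromatic ring.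

Within the data shown here, one measured step bears on this change: a 2.2-fold lower number from compound 1 to compound 3 (0.34 log units; beyond the scatter). It was modest, and it alone shows no trend. No step beyond the scatter is therefore expected in this assay. The expected step is a 1.0-fold higher number from compound 3 to compound 4 (0.01 log units; within the scatter). The estimated value for compound 4 is 300 nM, within a range of 140 nM to 620 nM.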

Compound 4, half-maximal inhibitory concentration: 660 nM
Estimate against measurement, compound 4: 2.2-fold (0.34 log units) below; measured number outside the range, above it.
By their numbers in this assay, from the lowest: compounds 3, 2, 1 and 4 (each within the scatter of the next, the first and the last beyond it).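

In this assay, (hydroxycarbamoyl)methyl in place of hydroxycarbamoyl at this chain carbon undoes the gain seen on the chain of compound 3 (a 2.3-fold higher number from compound 3 to compound 4 (0.36 log units; beyond the scatter)), so compound 3 stands apart from both compound 1 and compound 4. The two chain ends of this set are not separated (a 1.0-fold higher number from compound 1 to compound 4 (0.01 log units; within the scatter)), and hydrogen in place of methyl on an aromatic carbon also leaves no separation (a 1.5-fold higher number from compound 2 to compound 4 (0.18 log units; within the scatter)). No measurement here accounts for the reversal. From the compounds shown here alone, a still longer chain remains open, as does a carboxylic acid in place of the hydroxycarbamoyl end.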